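The source may report more compounds than this note shows. Statements on the series, on what has been measured and on what is new or still open speak of the compounds shown alone.

In an ADME assay on Caco-2 cells (Homo sapiens) for inhibition, read by MTT assay, with a stated time of 72 h (a higher number here means a weaker inhibitor, a lower number a stronger inhibitor), compound 1 (`C=CCNC(=C\C(=O)/C=C/c1ccc(O)c(OC)c1)/C=C/c1ccc(O)c(OC)c1`) gives > 25000 nM, which is a limit of the assay and not a number. Compound 2 (`COc1cc(/C=C/C(=O)/C=C(/C=C/c2ccc(O)c(OC)c2)NC2CCCCC2)ccc1O`) gives > 25000 nM, also a limit, so its place on this scale is bounded but not fixed. The unmeasured compound 3 (`CCCCNC(=C\C(=O)/C=C/c1ccc(O)c(OC)c1)/C=C/c1ccc(O)c(OC)c1`) differs from compound 2 at one place, with butyl in place of cyclohexyl on an amine nitrogen.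

Among the compounds with values here, only one measured step bears on this change, and it concerns the same amine nitrogen. It is a step that the two limits leave unreadable from compound 1 to compound 2, with cyclohexyl in place of allyl, so it offers no size to carry over. Within the data shown here, the values so far all sit at the limit of > 25000 nM in this assay, at which 2 of the 2 values shown sit, and allyl and cyclohexyl on this nitrogen have not produced a readable number. With nothing to indicate a direction, no step beyond the scatter is expected in this assay, and compound 3 will most likely also be reported only as a limit. The expected change is a step that the limit leaves unreadable from compound 2 to compound 3. For compound 3 the estimated value is 30000 nM, with an expected range from 12000 nM to 60000 nM.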

Compound 3, half-maximal inhibitory concentration: > 25000 nM
Compound 3 was reported as a limit (the forecaster's own chance of this, stated with the estimate: 70%); the middle value does not contradict the limit.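

In this assay compound 3 gives > 25000 nM, which is a limit of the assay and not a number. Within the data shown here, its steps from compound 1 and compound 2 cannot be read, so no new step follows. The compounds shown leave open whether allyl, cyclohexyl and butyl on the amine nitrogen differ at all in this measure.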